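Exchanging One Five-Membered Ring for Another

The source may hold more compounds than are shown below. What is called first, only, known or untested is meant among the compounds shown, and "the series" means these compounds.

Measured compounds:
compound 1 `CC(=O)Oc1ccc(-n2cccc2)cc1C(=O)O` — 42 mg/kg
compound 2 `O=C(O)c1cc(C2N=NN=N2)ccc1O` — 110 mg/kg

Of the compounds shown here, two have been tested in a functional assay on the whole organism for inhibition, with Rattus norvegicus as the target, read by paw edema; on this read-out higher numbers stand for an effect only at larger amounts of compound and lower numbers for an effect already at smaller amounts. There, compound 1 `CC(=O)Oc1ccc(-n2cccc2)cc1C(=O)O` gives 42 mg/kg, and compound 2 `O=C(O)c1cc(C2N=NN=N2)ccc1O` gives 110 mg/kg. Compound 2 stands at the highest of the two numbers; its nearest neighbour is compound 1, whose number is lower by a gap that lies beyond the usual scatter. Among the compounds with values here, these two structures differ in more than one place, so no single step between measured compounds can guide the next one.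

Compound 3 `O=C(O)c1cc(-n2cnnc2)ccc1O` has not yet been measured in this assay. It differs from compound 2 in one place: a group of 5 heavy atoms (2 carbon, 3 nitrogen; one five-membered aromatic ring with 3 hetero atoms) in place of a group of 5 heavy atoms (1 carbon, 4 nitrogen; one five-membered non-aromatic ring with 4 hetero atoms), on an aromatic carbon

Within the data shown here, with no comparable step on record, the change is judged on its own. The expected step of a 1.4-fold higher number from compound 2 to compound 3 (0.13 log units; within the scatter) is small, toward a slightly higher number, and hardly beyond the scatter. Compound 3 is therefore estimated at 150 mg/kg, within a range from 60 mg/kg to 400 mg/kg.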

Compound 3, dose for half-maximal effect: > 250 mg/kg
Compound 3 was reported as a limit; the forecaster's own chance of this, stated with the estimate: 10%; at least 1.6-fold (0.22 log units) between middle value and limit.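

In this assay, the aromatic carbon para to the hydroxy group proves sensitive to which five-membered ring it carries: exchanging the non-aromatic ring with four nitrogens for 4H-1,2,4-triazol-4-yl gives an at least 2.2-fold higher number from compound 2 to compound 3 (0.35 log units; beyond the scatter). Within the data shown here, this is the first single change on record at this position, as compound 1 and compound 2 differ in more than one place, and it shows that keeping the ring size and the heavy-atom count does not keep the read-out of compound 2. Compound 3 is reported as a limit, so the step fixes a direction but no exact size, because the read-out gives no number there: the limit of > 250 mg/kg in this assay, at which 1 of the 3 values shown sits.

The two rings differ in both nitrogen count and aromatic character, so the compounds shown cannot separate these two changes. Nor do they tell how an amine or a longer chain on this aromatic carbon would read in this assay.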